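The source may report more compounds than this note shows. Statements on the series, on what has been measured and on what is new or still open speak of the compounds shown alone.

Measured compounds:
Compound 1 `CN(C(=O)c1ccc(Cl)cc1)c1ccc2[nH]c(-c3n[nH]c4ccccc34)cc2n1`: 450 nM
Compound 2 `COc1ccc(S(=O)(=O)N(C)c2ccc3[nH]c(-c4n[nH]c5ccccc45)cc3n2)cc1`: 4340 nM
Compound 3 `CN(c1ccc2[nH]c(-c3n[nH]c4ccccc34)cc2n1)S(=O)(=O)c1cccc([N+](=O)[O-])c1`: 3660 nM

In a functional assay on HL-60 cells (Homo sapiens) for antiproliferative activity, read by MTT assay, with a stated time of 72 h (on this read-out lower numbers stand for stronger inhibition and higher numbers for weaker inhibition), compound 1 gives the lowest number of the three, so it inhibits growth most strongly here; compound 3 and compound 2 both sit well above it. The unmeasured compound 4 `CN(C(=O)Nc1ccccc1)c1ccc2[nH]c(-c3n[nH]c4ccccc34)cc2n1` differs from compound 1 in one place: anilino in place of 4-chlorophenyl on a carbonyl carbon. Going by the values given here, no measured step covers this kind of change. Among the compounds with values here, the only measured step, a 1.2-fold lower number from compound 2 to compound 3 (0.07 log units; within the scatter), swaps one ring on a sulfonyl sulfur and stays within the scatter, which offers no guidance for a carbonyl carbon. Given that, compound 4 is expected to stay near compound 1, with a step of a 1.8-fold higher number from compound 1 to compound 4 (0.25 log units; within the scatter) that may well fall within the scatter. Compound 4 is therefore estimated at 800 nM, in the range 250 nM to 2500 nM.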

Compound 4, half-maximal inhibitory concentration: 8.3 nM
Beside the measured number, compound 4's estimate is 96-fold (1.98 log units) above it; measured number outside the range, below it.
By their numbers in this assay, from the lowest: compound 4; then compound 1; then compounds 3 and 2 (each within the scatter of the next).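

In this assay, the group on this carbonyl carbon proves to matter greatly: anilino in place of 4-chlorophenyl gives a 54-fold lower number from compound 1 to compound 4 (1.73 log units; beyond the scatter). The swap keeps a six-membered aromatic ring of carbon only, but brings in a nitrogen and a hydrogen-bond donor, so even a change of similar size can shift the number sharply. Nothing measured here explains the gain. The compounds shown leave open whether it follows the nitrogen or the ring. A cyclohexylamino or benzylamino group on the same carbonyl carbon would help separate the two.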